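From 4-chlorophenyl to 3-methoxyphenyl on the shared core

The compounds below may be only part of what the source reports. "The series", "measured", "known", "first", "only" and "open" are said of these compounds alone.

Compound 1 `Oc1ccc2ccccc2c1C(Nc1nc2ccccc2s1)c1cn(-c2ccccc2)nc1-c1ccccc1` gives 17300 nM in the first measurement
Compound 2 `COc1ccc2nc(NC(c3cn(-c4ccccc4)nc3-c3ccc(Cl)cc3)c3c(O)ccc4ccccc34)sc2c1` gives 5200 nM in the second measurement

Both numbers come from a functional assay on HeLa cells (Homo sapiens) for antiproliferative activity, read by MTT assay, with a stated time of 48 h (a lower number here means a stronger inhibitor, a higher number a weaker inhibitor), and so far only these two compounds have been tested there. Compound 2 stands lowest of the two, and its gap to compound 1 lies beyond the usual scatter. The two differ in more than one place, so their values cannot be tied to any single change. Compound 3 `COc1cccc(-c2nn(-c3ccccc3)cc2C(Nc2nc3ccc(OC)cc3s2)c2c(O)ccc3ccccc23)c1` has not yet been measured. It carries 3-methoxyphenyl in place of 4-chlorophenyl on an aromatic carbon of a five-membered aromatic ring with 2 nitrogen (3-methoxyphenyl in place of 4-chlorophenyl on an aromatic carbon). Going by the values given here, no measured pair shows what this exchange does, so the expectation starts from compound 2 at 5200 nM and assumes no shift beyond the scatter in this assay in either direction. The expected step is small (a 1.2-fold higher number from compound 2 to compound 3 (0.06 log units; within the scatter)). For compound 3 the estimated value is 6000 nM with a wide expected range (2200 nM to 16000 nM).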

Compound 3, half-maximal inhibitory concentration: 10500 nM
Beside the measured number, compound 3's estimate is 1.8-fold (0.24 log units) below it; the range from low to high includes it.
By their numbers in this assay, from the lowest: compound 2; then compounds 3 and 1 (each within the scatter of the next).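

In this assay, going by these compounds alone, the exchange of 4-chlorophenyl for 3-methoxyphenyl on an aromatic carbon of the five-membered ring gives a 2.0-fold higher number from compound 2 to compound 3 (0.31 log units; beyond the scatter) and provides the first comparison in this set in which only one place differs, showing that the number responds to the group carried at this position, though the step is modest. The entering group differs from the leaving group in both the identity and the placement of its substituent on the phenyl ring, so this single pair cannot separate a change of chlorine to methoxy from a change in where the substituent sits. Nothing measured here accounts for the step.

The compounds shown leave open whether 3-chlorophenyl or 4-methoxyphenyl at this carbon would resolve those two changes, and whether an amine or a carboxylic acid on the same phenyl ring would move the number in either direction. Compound 1 differs from the other two compounds in more than one place, so it does not settle what the bare phenyl contributes at this position.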